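This account rests on a few compounds, and the source may have more. Where it says the series, first, only, none or still open, it means among the compounds named here.

Three compounds that share one core and differ only in a single substituted phenyl group have been tested in a functional assay on KBVIN cells (Homo sapiens) for antiproliferative activity, read by sulforhodamine B assay, with a stated time of 3 days; a higher number here means that more compound is needed for the effect, a lower number that less compound is needed. Compound 1 `CCC1=C(O)c2c(oc(-c3ccc(SC)cc3)cc2=O)C(CC)(CC)C1=O` gives 1.38 uM, compound 2 `CCC1=C(O)c2c(oc(-c3ccccc3OC)cc2=O)C(CC)(CC)C1=O` gives 3.26 uM, and compound 3 `CCC1=C(O)c2c(oc(-c3ccc(C)cc3C)cc2=O)C(CC)(CC)C1=O` gives 8.52 uM, the highest number of the three. The next change leads to compound 4 `CCC1=C(O)c2c(oc(-c3ccc(C)c(Cl)c3)cc2=O)C(CC)(CC)C1=O`, with 3-chloro-4-methylphenyl in place of 2,4-dimethylphenyl on an aromatic carbon.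

For the measured compounds named here, two measured steps bear on this change, as both involve the 2,4-dimethylphenyl group at the same place: a 2.6-fold higher number from compound 2 to compound 3 (0.42 log units; beyond the scatter) and a 6.2-fold higher number from compound 1 to compound 3 (0.79 log units; beyond the scatter). Read in reverse, each shows another substituted phenyl group giving a lower number than compound 3, by a modest amount. Neither of those groups carries chlorine, so these steps are only a rough guide. The expected change is a 2.4-fold lower number from compound 3 to compound 4 (0.39 log units; beyond the scatter), a modest move to a lower number, close in size to the smaller measured step. In this assay the estimate for compound 4 is 3.5 uM, with an expected range of 1.3 uM to 9 uM.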

Compound 4, concentration for half-maximal effect: 2.15 uM
Estimate against measurement, compound 4: 1.6-fold (0.21 log units) above; the measured number falls inside the stated range.
By their numbers in this assay, from the lowest: compounds 1, 4 and 2 (each within the scatter of the next, the first and the last beyond it); then compound 3.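

For the compounds shown here, the first chlorine-bearing group at this position brings a clear gain over 2,4-dimethylphenyl, with a 4.0-fold lower number from compound 3 to compound 4 (0.60 log units; beyond the scatter), so the high number of compound 3 does not carry over to every disubstituted phenyl group here. Compound 4 also lands close to both other groups, with a 1.5-fold lower number from compound 2 to compound 4 (0.18 log units; within the scatter) and a 1.6-fold higher number from compound 1 to compound 4 (0.19 log units; within the scatter), and both steps lie within the scatter, so no order can be drawn within either pair. No supporting measurement explains the gain from compound 3 to compound 4.

As far as these compounds go, the change removes the 2-methyl and adds the 3-chloro at once, so the share of each in that step remains open. Also open, from the compounds shown here alone, is how a phenyl group carrying an amine or a carboxylic acid would behave at this position.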